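Swapping Dichloro for Difluoro on the Sulfonyl Phenyl

The compounds below may be only part of what the source reports. "The series", "measured", "known", "first", "only" and "open" are said of these compounds alone.

The measured compounds and their results in an assay on isolated protein for displacement of a labelled ligand from metabotropic glutamate receptor 5 (Homo sapiens), with a stated time of 60 min, tested at 1 uM (a lower number here means less inhibition, a higher number more inhibition at the concentration tested (going by the name of the read-out)), are:
compound 1, `CC1CCN(c2c(S(=O)(=O)c3ccc(Cl)c(Cl)c3)cnc3ccc(F)cc23)CC1`: 91%
compound 2, `CC1CCN(c2c(S(=O)(=O)c3ccc(F)c(F)c3)cnc3ccc(F)cc23)CC1`: 82%
compound 3, `CC1CCN(c2c(S(=O)(=O)c3ccc(Cl)c(Cl)c3)cnc3c(F)cccc23)CC1`: 95%

Compounds 1 and 2 share one core and differ only in the group on the sulfonyl sulfur. That change, (3,4-difluorophenyl in place of 3,4-dichlorophenyl on a sulfonyl sulfur), moved the read-out in this assay by a number 9 percentage points lower from compound 1 to compound 2 (within the scatter), so the two values sit within the usual scatter and no order can be read between them.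

Compound 3 carries the same 3,4-dichlorophenyl as compound 1 on a different core; compounds 1 and 3 contain the same atoms joined differently, and the difference between the two cores is not broken down here. Compound 3 has the highest number of the three, but its step to compound 1 is within the scatter, and only the gap to compound 2 lies beyond it.

Compound 4, `CC1CCN(c2c(S(=O)(=O)c3ccc(F)c(F)c3)cnc3c(F)cccc23)CC1`, is not yet measured. It relates to compound 3 as compound 2 relates to compound 1: the change is 3,4-difluorophenyl in place of 3,4-dichlorophenyl on a sulfonyl sulfur, the same change on the same kind of place. The expected step from compound 3 to compound 4 in this assay is estimated at a number 9 percentage points lower from compound 3 to compound 4 (within the scatter), resting on the earlier step from compound 1 to compound 2 of a number 9 percentage points lower from compound 1 to compound 2 (within the scatter). Compound 4 is therefore expected to give about 86%, with a plausible range from 76% to 94%.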

Compound 4, a percentage reported as inhibition, at one concentration (the size of the read-out at that concentration, not a potency): 93%
Estimate against measurement, compound 4: 7 percentage points below, within the range that was stated.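

In this assay, the change to 3,4-difluorophenyl in place of 3,4-dichlorophenyl on a sulfonyl sulfur, carried over to the second core, moved the read-out by a number 2 percentage points lower from compound 3 to compound 4 (within the scatter). Set beside the earlier step, the new one does not differ from it, so in this series the change behaves alike on the two cores as far as these numbers can tell: the same change on two cores in this assay, a number 9 percentage points lower (within the scatter) from compound 1 to compound 2 and a number 2 percentage points lower (within the scatter) from compound 3 to compound 4, 7 percentage points apart, within the scatter of two such steps. Among the compounds shown here, this does not show that the change has a real effect on either core, since neither step can be told from scatter, and the agreement rests on only two pairs and on a read-out taken at one concentration, which gives no potency and could hide differences between the compounds.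

The compounds shown leave open how the two cores would respond to other groups on the sulfonyl sulfur, such as a plain phenyl, a mixed 3-chloro-4-fluorophenyl, a methoxyphenyl or a pyridine ring. They also leave open whether the agreement would hold for a change elsewhere in the molecule, such as an open-chain amine in place of the ring amine that all four compounds share.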